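The source may hold more compounds than are shown below. What is called first, only, known or untested is meant among the compounds shown, and "the series" means these compounds.

Measured compounds:
Compound 1, `COc1ccc(NCN2C(=O)c3ccccc3C2=O)cc1`: 97.2%
Compound 2, `COc1ccc(NCN2C(=O)c3ccc(NC(=O)c4ccccc4)cc3C2=O)cc1`: 82%

Both were tested in an assay on isolated protein for inhibition of ribosomal protein S6 kinase alpha-2 (Homo sapiens), read by fluorescence, with a stated time of 20 min, tested at 10 uM; a lower number here means less inhibition, a higher number more inhibition at the concentration tested (going by the name of the read-out). Going by the values given here, compound 2 stands at the lower of the two numbers, with compound 1 above it: the single measured step, a number 15.2 percentage points lower from compound 1 to compound 2 (beyond the scatter), follows the introduction of benzamido in place of hydrogen on an aromatic carbon, and it lies beyond the scatter though it is modest in size.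

Compound 3, `COc1ccc(NCN2C(=O)c3ccc(NC(=O)Nc4ccccc4)cc3C2=O)cc1`, is not yet measured. It differs from compound 2 by anilino in place of phenyl on a carbonyl carbon, so the benzamido of compound 2 becomes (phenylcarbamoyl)amino. Among the compounds with values here, the only measured step, a number 15.2 percentage points lower from compound 1 to compound 2 (beyond the scatter), concerns the addition of that same group rather than its reshaping, so it bears on the new step only loosely. The account therefore expects no step beyond the scatter for a number 2 percentage points lower from compound 2 to compound 3 (within the scatter), in either direction. Compound 3 is estimated at 80% in this assay, within a range from 60% to 95%.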

Compound 3, a percentage reported as inhibition, at one concentration (the size of the read-out at that concentration, not a potency): 34.8%
Estimate against measurement, compound 3: 45.2 percentage points above, and the stated range ends above it.
By their numbers in this assay, from the lowest: compound 3; then compound 2; then compound 1.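

Anilino in place of phenyl on a carbonyl carbon adds only a single nitrogen to the group, yet in this assay it gives a number 47.2 percentage points lower from compound 2 to compound 3 (beyond the scatter) as a large step. The place therefore responds to what the group is and not merely to its presence: benzamido gave a number 15.2 percentage points lower from compound 1 to compound 2 (beyond the scatter) as a modest step, whereas (phenylcarbamoyl)amino in place of hydrogen on an aromatic carbon gives a number 62.4 percentage points lower from compound 1 to compound 3 (beyond the scatter) as a large one. Nothing measured here explains why the added nitrogen has so large an effect.

Going by these compounds, it remains open whether the drop follows the nitrogen itself or its hydrogen, which a methyl on that nitrogen or an oxygen in its place, as in a carbamate, could separate. These single-concentration readings also leave open how the three compounds compare in potency.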